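Replacing an Ether Side Chain with Cyclopropyl

The source may hold more compounds than are shown below. What is called first, only, known or untested is meant among the compounds shown, and "the series" means these compounds.

Of the compounds shown here, two have so far been measured in a functional assay on HEK293 cells for antagonist activity at Oxytocin receptor (Homo sapiens), read by calcium flux, with a stated time of 10 min, in the presence of a further agent that is not named here; a higher number here means a weaker inhibitor, a lower number a stronger inhibitor. Compound 1 `COCc1nnc(N2CC3CN(c4ccc(F)cc4Cl)CC32)n1-c1ccc(OC)nc1` gives 850 nM in this assay, while compound 2 `COc1ccc(-n2c(CO[C@H]3CCOC3)nnc2N2C[C@@H]3C[C@]3(c3ccc(F)cc3Cl)C2)cn1` gives 184 nM. Compound 2 therefore stands at the lower of the two numbers, and compound 1 sits well above it, a gap beyond the usual scatter of repeated measurements. The next compound, compound 3 `COc1ccc(-n2c(C3CC3)nnc2N2C[C@@H]3C[C@]3(c3ccc(F)cc3Cl)C2)cn1`, differs from compound 2 in a single place: cyclopropyl in place of ((oxolan-3-yl)oxy)methyl on an aromatic carbon. Going by the values given here, no measured pair shows this exchange, so its size is not fixed by the data. The author expects the step of a 1.7-fold higher number from compound 2 to compound 3 (0.24 log units; within the scatter) to be a modest rise in this assay, only somewhat beyond the scatter. Compound 3 is accordingly estimated at 320 nM, with a plausible range from 90 nM to 1200 nM.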

Compound 3, half-maximal inhibitory concentration: 433 nM
Estimate against measurement, compound 3: 1.4-fold (0.13 log units) below; the measured number falls inside the stated range.
By their numbers in this assay, from the lowest: compound 2; then compounds 3 and 1 (each within the scatter of the next).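

In this assay the position on the aromatic carbon between two ring nitrogen atoms proves sensitive to its substituent, since a 2.4-fold higher number from compound 2 to compound 3 (0.37 log units; beyond the scatter) is a modest loss that lies beyond the scatter. The exchange is also tolerated to a degree: with the oxygen-bearing ((oxolan-3-yl)oxy)methyl chain gone and only an all-carbon cyclopropyl in its place, compound 3 still inhibits at 433 nM in this assay. No measurement available here explains the size of this step.

Going by these compounds alone, the single exchange changes the size, the oxygen atoms and the ring at once, so it leaves open which of these accounts for the difference. It also leaves open how this position would respond to a simple amine, a carboxylic acid or a longer unbranched alkyl chain on the same core.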